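Swapping a fluorophenyl for pyridinyl on the imine

This account rests on a few compounds, and the source may have more. Where it says the series, first, only, none or still open, it means among the compounds named here.

Measured so far:
Compound 1, `CC1CC(/C=N/c2ccccc2C(=O)O)=C2NC=C(C(=O)O)C(=O)N2C1`, 48.1 umol/kg
Compound 2, `CC1CCC(/C=N/c2ccccc2F)=C2NC=C(C(=O)O)C(=O)N21`, 14.5 umol/kg

Both compounds share a bicyclic core carrying a carboxylic acid and an imine, and they differ in the aromatic group attached to the double-bonded nitrogen. In a functional assay on the whole organism with Rattus norvegicus as the target (on this read-out lower numbers stand for an effect already at smaller amounts and higher numbers for an effect only at larger amounts of compound), compound 1 gives 48.1 umol/kg, while compound 2 gives 14.5 umol/kg. Compound 2 therefore stands at the lowest number of the two, and the gap to compound 1 lies beyond the usual scatter of repeated measurements, so compound 2 is the more potent of the pair on this read-out.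

The next compound, compound 3, has the structure `CC1CCC(/C=N/c2cccnc2)=C2NC=C(C(=O)O)C(=O)N21`. It differs from compound 2 in a single place: pyridin-3-yl in place of 2-fluorophenyl on a double-bonded nitrogen. For the measured compounds named here, no measured pair shows what such a change does on this read-out, so there is no direct guide for the size or direction of the step.

Going by the values given here, with only two measured compounds, the expectation rests on the value of compound 2, 14.5 umol/kg, and on the small size of the change. Compound 3 is expected to sit close to compound 2, with an estimated step of a 1.4-fold higher number from compound 2 to compound 3 (0.14 log units; within the scatter) that does not clearly exceed the scatter. The estimate for compound 3 is 20 umol/kg, with a range from 7 umol/kg to 60 umol/kg.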

Compound 3, dose for 50% inhibition: 2.4 umol/kg
For compound 3 the middle estimate is 8.3-fold (0.92 log units) above the measured one, and the stated range ends above it.
By their numbers in this assay, from the lowest: compound 3; then compound 2; then compound 1.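

In this assay, the aromatic group on the double-bonded nitrogen proves able to shift the result: pyridin-3-yl in place of 2-fluorophenyl gives a 6.0-fold lower number from compound 2 to compound 3 (0.78 log units; beyond the scatter), a step beyond the scatter. For the compounds shown here, this is the first comparison here in which only one place changes, so this difference can be tied to that single swap, whereas compound 1 and compound 2 differ in more than one place. The swap removes the fluorine and puts a nitrogen into the ring, which adds a hydrogen-bond acceptor to the count, but a single step cannot show which of these changes matters. No measurement at hand bears on why the number falls.

A plain phenyl group at this place would help separate the loss of the fluorine from the gain of the ring nitrogen, while pyridin-2-yl and pyridin-4-yl would test whether the location of that nitrogen matters. On these data alone, it also remains open whether pyridin-3-yl would give a similar step on the core of compound 1, since a single pair cannot establish a general pattern.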